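A few compounds are considered here, and "the series" means these few. Any claim that something is new, unique, unknown or untested is made for them only; others in the source may bear on it.

Measured compounds:
compound 1, `CC1=NN(c2ccccc2)C(=O)[C@]12C(=O)C=CC[C@H]2c1ccc(C)cc1`, 4220 nM
compound 2, `CC1=NN(c2ccccc2)C(=O)[C@@]12C(=O)C=CC[C@@H]2c1ccc(C)cc1`, 5220 nM
compound 3, `CC1=NN(c2ccccc2)C(=O)[C@@]12C(=O)C=CC[C@@H]2c1ccccc1`, 6070 nM

All three were tested in a functional assay on HCT-116 cells (Homo sapiens) for inhibition, read by MTT assay, with a stated time of 72 h; on this read-out higher numbers stand for weaker inhibition and lower numbers for stronger inhibition. Compound 1 and compound 2 are mirror images, a pair that differs only in the configuration as drawn, and the step of a 1.2-fold higher number from compound 1 to compound 2 (0.09 log units; within the scatter) is small; given (the fact that compounds 1 and 2 differ only in the configuration as drawn), the drawn configuration makes no difference that the scatter can resolve. Compound 3 carries the unsubstituted phenyl on the saturated ring carbon, and the change to compound 2 is methyl in place of hydrogen on an aromatic carbon; that step, a 1.2-fold lower number from compound 3 to compound 2 (0.07 log units; within the scatter), also lies within the scatter. The difference between the cores of compound 1 and compound 3 is not broken down here; their values lie close to each other.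

Compound 4, `CC1=NN(c2ccc(C)cc2)C(=O)[C@]12C(=O)C=CC[C@H]2c1ccc(C)cc1`, has not yet been measured. It is derived from compound 1 by methyl in place of hydrogen on an aromatic carbon, the same change that separates compound 3 from compound 2, now made on the phenyl attached to the ring nitrogen. Going by the values given here, since the earlier instance of this change produced only the step of a 1.2-fold lower number from compound 3 to compound 2 (0.07 log units; within the scatter), compound 4 is expected to show a step of a 1.1-fold lower number from compound 1 to compound 4 (0.05 log units; within the scatter), essentially the value of compound 1 again. In this assay compound 4 is therefore estimated at 3800 nM, with a likely range from 1800 nM to 8000 nM.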

Compound 4, half-maximal inhibitory concentration: 3530 nM
The estimate for compound 4 lay 1.1-fold (0.03 log units) above the measured number; measured number inside the range.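

In this assay, replacing phenyl with 4-methylphenyl gives a 1.2-fold lower number from compound 1 to compound 4 (0.08 log units; within the scatter), so the added methyl does not separate compound 4 from compound 1. The same replacement of hydrogen by methyl on an aromatic carbon gives a step of matching size on the two cores, and the two steps cannot be told apart: the same change on two cores in this assay, a 1.2-fold lower number (0.07 log units; within the scatter) from compound 3 to compound 2 and a 1.2-fold lower number (0.08 log units; within the scatter) from compound 1 to compound 4, 1.0-fold (0.01 log units) apart, within the scatter of two such steps This shows that, across these two instances, the change carries over without a resolved effect, but it does not show that methyl improves inhibition, since neither step rises above the scatter, and two instances set no rule for other cores in the series.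

The compounds shown leave open whether a larger or differently built group on these aromatic rings, such as methoxy, an amine or a carboxylic acid, would move the number beyond the scatter, as methyl does not. They also leave open whether the agreement between the two steps would hold on a core that differs further from those of compound 1 and compound 3, or in a read-out on any other cell line.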